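Sigma receptor series: piperidine nitrogen substituent, compound 3 estimate

The source may report more compounds than this note shows. Statements on the series, on what has been measured and on what is new or still open speak of the compounds shown alone.

Measured so far:
compound 1 `[O-][S+](CCNC1CCN(CC(O)Cc2ccccc2)CC1)C(c1ccc(F)cc1)c1ccc(F)cc1` gives 351 nM
compound 2 `CC(C)(C)C(=O)N1CCC(NCCSC(c2ccc(F)cc2)c2ccc(F)cc2)CC1` gives 163 nM

In an assay on membranes from Cortex for displacement of a labelled ligand from Sigma non-opioid intracellular receptor 1 (Cavia porcellus), read by scintillation counting, with a stated time of 120 min (a higher number here means a weaker inhibitor, a lower number a stronger inhibitor), compound 1 gives 351 nM, the highest of the two numbers; compound 2 gives 163 nM, a gap beyond the scatter. Compound 2 differs from compound 1 in more than one place, so its value serves only as a hint. Compound 3 `O=C(c1ccc(F)cc1F)N1CCC(NCC[S+]([O-])C(c2ccc(F)cc2)c2ccc(F)cc2)CC1` carries (2,4-difluorophenyl)carbonyl in place of 2-hydroxy-3-phenylpropyl on an amine nitrogen in a ring. Among the measured compounds shown here, no single-site step is measured here; a modest move toward a lower number is expected, since compound 2, with an amide on the same ring nitrogen, gives 163 nM. Compound 3 is expected at 220 nM (range 70 nM to 700 nM), meaning the step of a 1.6-fold lower number from compound 1 to compound 3 (0.20 log units; within the scatter).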

Compound 3, inhibition constant: 171 nM
Compound 3: the middle estimate sits 1.3-fold (0.11 log units) above what was measured, within the range that was stated.
By their numbers in this assay, from the lowest: compounds 2 and 3 (each within the scatter of the next); then compound 1.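

In this assay, among the compounds shown here, (2,4-difluorophenyl)carbonyl in place of 2-hydroxy-3-phenylpropyl on the ring amine nitrogen gives a 2.1-fold lower number from compound 1 to compound 3 (0.31 log units; beyond the scatter) and is the first single-site step read at this position, modest in size. The change is composite: a hydrogen-bond donor leaves, while a carbonyl and two fluorine atoms enter, so the step cannot be assigned to any one of these. No measurement shown bears on the reason for this step.

Open: how a benzoyl group without fluorine, or a benzyl group, on the same nitrogen would read against compound 1.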